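This account rests on a few compounds, and the source may have more. Where it says the series, first, only, none or still open, it means among the compounds named here.

Working notes on the series.

Three compounds are measured. Compound 1 `O=C(Nc1cc(Cl)nc(Cl)c1)Nc1cc2ccc(-c3ccccc3)cn2n1` and compound 2 `COc1ccc(-c2ccc3cc(NC(=O)Nc4cc(Cl)nc(Cl)c4)nn3c2)cc1` share one core; compound 3 `O=C(Nc1cc(Cl)cc(Cl)c1)Nc1cc(Cl)nc(Cl)c1` is built on another, and the difference between the two cores is not broken down here. In an ADME assay on NCM460 cells (Homo sapiens) for cytotoxicity, read by MTT assay, with a stated time of 72 h, in the presence of a further agent that is not named here (a higher number here means that more compound is needed for the effect, a lower number that less compound is needed), compound 1 gives 8050 nM and compound 2 gives 8350 nM. In this assay compound 3 gives 55400 nM, a number that lies beyond the scatter from both compound 1 and compound 2, so compound 3 needs the most compound for the effect among the three.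

One counted step connects measured compounds: methoxy in place of hydrogen on an aromatic carbon, which gave a 1.0-fold higher number from compound 1 to compound 2 (0.02 log units; within the scatter).

Compound 4 `COc1c(Cl)cc(NC(=O)Nc2cc(Cl)nc(Cl)c2)cc1Cl` is not yet measured. It differs from compound 3 by methoxy in place of hydrogen on an aromatic carbon. Among the measured compounds shown here, this is the same kind of change as the one from compound 1 to compound 2, not the same: in compound 4 the methoxy sits ortho to two chloro groups (1 heavy atom each) and para to a large group, whereas in compound 2 it sits para to a large group only.

For the measured compounds named here, the step from compound 3 to compound 4 is expected to be small, a 1.1-fold lower number from compound 3 to compound 4 (0.04 log units; within the scatter), because a 1.0-fold higher number from compound 1 to compound 2 (0.02 log units; within the scatter) stayed within the scatter on the other core, although the surroundings of the place differ and only one such step is on hand. Compound 4 is therefore expected to give about 50000 nM, with a likely range from 22000 nM to 110000 nM.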

Compound 4, half-maximal effective concentration: 27300 nM
Estimate against measurement, compound 4: 1.8-fold (0.26 log units) above, within the range that was stated.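

In this assay, methoxy in place of hydrogen on an aromatic carbon gives a 2.0-fold lower number from compound 3 to compound 4 (0.31 log units; beyond the scatter), a modest step that lies just beyond the scatter, whereas the same change on the core of compound 1 stayed within it. Set side by side, the two steps cannot be told apart, so the series gives no sign that the outcome of this change depends on the core: the same change on two cores in this assay, a 1.0-fold higher number (0.02 log units; within the scatter) from compound 1 to compound 2 and a 2.0-fold lower number (0.31 log units; beyond the scatter) from compound 3 to compound 4, 2.1-fold (0.32 log units) apart, within the scatter of two such steps

This does not show that the change transfers reliably, since it rests on one pair per core, and the surroundings of the place differ, with the methoxy of compound 4 ortho to two chloro groups and para to a large group and that of compound 2 para to a large group only; the data cannot separate a contribution of the core from one of those surroundings.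

The compounds shown leave open whether any other group at these places would move the number further in either direction, such as a hydroxyl, an amine, a carboxylic acid or a longer alkoxy chain. They also leave open whether the small size of the step holds on a third core.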